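Chloro Substitution on a Sulfonamide Core, Two Placements

The source may report more compounds than this note shows. Statements on the series, on what has been measured and on what is new or still open speak of the compounds shown alone.

The measured compounds:
compound 1, `O=S(=O)(Nc1cccc2cc[nH]c12)c1ccc(Cl)cc1`, 7 ug/mL
compound 2, `O=S(=O)(Nc1ccc(Cl)c2cc[nH]c12)c1ccc(Cl)cc1`, 0.66 ug/mL
compound 3, `Nc1ccc(S(=O)(=O)Nc2cccc3cc[nH]c23)cc1`, 6.1 ug/mL

All three were tested in a functional assay on MC-38 cells (Mus musculus) for antiproliferative activity, read by colorimetric assay and MTT assay; a lower number here means a stronger inhibitor, a higher number a weaker inhibitor. Compound 1 gives 7 ug/mL in this assay, compound 2 gives 0.66 ug/mL and compound 3 gives 6.1 ug/mL. The step from compound 1 to compound 2 is chloro in place of hydrogen on an aromatic carbon, and it produced an 11-fold lower number from compound 1 to compound 2 (1.03 log units; beyond the scatter). The step from compound 1 to compound 3 is amino in place of chloro on an aromatic carbon, with a 1.1-fold lower number from compound 1 to compound 3 (0.06 log units; within the scatter), so compounds 1 and 3 are not separated by their numbers.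

Compound 4, `Nc1ccc(S(=O)(=O)Nc2cccc3c(Cl)c[nH]c23)cc1`, is not yet measured. It differs from compound 3 by chloro in place of hydrogen on an aromatic carbon. For the measured compounds named here, this is the same kind of change as the one from compound 1 to compound 2, but not the same: there the chloro entered on a six-membered aromatic ring of carbon only, ortho to a fused ring, meta to a fused ring and para to a large group, whereas here it enters on a five-membered aromatic ring with one nitrogen, two ring bonds from the ring nitrogen. The two cores differ by amino in place of chloro on an aromatic carbon, and compounds 1 and 3 sit within the scatter of each other.

Because of an 11-fold lower number from compound 1 to compound 2 (1.03 log units; beyond the scatter) a lower number is expected for compound 4 than for compound 3, but since the place of the chloro is not the same, the expected step is smaller: a 2.4-fold lower number from compound 3 to compound 4 (0.39 log units; beyond the scatter). Compound 4 is estimated at 2.5 ug/mL, with a range from 0.7 ug/mL to 6.5 ug/mL.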

Compound 4, half-maximal inhibitory concentration: 0.23 ug/mL
For compound 4 the middle estimate is 11-fold (1.04 log units) above the measured one; the whole stated range lies above it.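

In this assay, chloro in place of hydrogen on an aromatic carbon of the five-membered aromatic ring, two ring bonds from the ring nitrogen, gave a 27-fold lower number from compound 3 to compound 4 (1.42 log units; beyond the scatter), a large step in the same direction as the earlier one. The change therefore carried over from one core to the other in these two pairs, with both steps large and no separation in size between them beyond what two such steps would scatter: the same change on two cores in this assay, an 11-fold lower number (1.03 log units; beyond the scatter) from compound 1 to compound 2 and a 27-fold lower number (1.42 log units; beyond the scatter) from compound 3 to compound 4, 2.5-fold (0.40 log units) apart, within the scatter of two such steps

For the compounds shown here, this does not show that the step size is a constant of the series, as it rests on only two pairs, which differ both in the core and in the place where the chloro enters, so the effects of core and place cannot be told apart.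

On these data alone, it remains open what each core would give with the chloro at the place it holds on the other core, which is the comparison that would separate these two factors. Also open, as far as these compounds go, is whether a bromo or a methyl group on the same aromatic carbon would give a step of similar size, and how the chloro step would behave with a carboxylic acid or a methoxy group in place of the amino group of compound 3.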